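This account rests on a few compounds, and the source may have more. Where it says the series, first, only, none or still open, it means among the compounds named here.

Working notes on the series. In a functional assay on NCI-H322M cells (Homo sapiens) for inhibition, read by sulforhodamine B assay, with a stated time of 48 h (on this read-out higher numbers stand for lower toxicity in this test and lower numbers for higher toxicity in this test), compound 2 `COc1ccc(-c2cc(/C=C/C(=O)c3ccc(N)cc3)[nH]n2)cc1OC` gives 46200 nM and compound 1 `COc1ccc(-c2cc(/C=C/C(=O)c3ccc(N)cc3)[nH]n2)cc1` gives 31600 nM; the change between them is hydrogen in place of methoxy on an aromatic carbon and the step is a 1.5-fold lower number from compound 2 to compound 1 (0.16 log units; within the scatter). In this assay compound 3 `COc1cc(C(=O)/C=C/c2cc(-c3cc(OC)c(OC)c(OC)c3)n[nH]2)cc(OC)c1OC` gives 14400 nM, the lowest number of the three. How the core of compound 3 differs from the core of compound 2 is not broken down here. Compound 4 `COc1ccc(-c2cc(/C=C/C(=O)c3cc(OC)c(OC)c(OC)c3)[nH]n2)cc1OC` is not yet measured and differs from compound 3 by hydrogen in place of methoxy on an aromatic carbon, the same kind of change as that between compound 2 and compound 1, though here the place is in addition meta to a methoxy group. Because a 1.5-fold lower number from compound 2 to compound 1 (0.16 log units; within the scatter) lay within the scatter, a step of similar size is expected for compound 4, a 1.2-fold lower number from compound 3 to compound 4 (0.08 log units; within the scatter). In this assay compound 4 is estimated at 12000 nM, between 5000 nM and 30000 nM.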

Compound 4, concentration lethal to 50% of the cells: 25000 nM
Estimate against measurement, compound 4: 2.1-fold (0.32 log units) below, within the range that was stated.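

In this assay, hydrogen in place of methoxy on an aromatic carbon gives a 1.7-fold higher number from compound 3 to compound 4 (0.24 log units; within the scatter), and this step does not differ beyond the scatter from the one seen on the other core: the same change on two cores in this assay, a 1.5-fold lower number (0.16 log units; within the scatter) from compound 2 to compound 1 and a 1.7-fold higher number (0.24 log units; within the scatter) from compound 3 to compound 4, 2.5-fold (0.40 log units) apart, within the scatter of two such steps

On these two cores, the change therefore carries over as a step too small to read, with no sign that the core alters it. This does not show that the change has no effect in general or that it would stay this small on another core, since it rests on just two pairs, each step within the scatter.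

The compounds shown carry only methoxy or hydrogen at the changed places. On these data alone, what a hydroxyl group, a chlorine atom or a longer alkoxy chain would do there remains open.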